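The compounds below may be only part of what the source reports. "The series", "measured", "known", "first", "only" and "open" are said of these compounds alone.

Measured compounds in an assay on isolated protein for inhibition of Indoleamine 2,3-dioxygenase 1 (Homo sapiens), read by colorimetric assay, with stated times of 10 min and 30 min, tested at 100 uM; a lower number here means less inhibition, a higher number more inhibition at the concentration tested (going by the name of the read-out):

compound 1 `Fc1ccccc1-c1c[nH]c(=S)s1` gives 29%
compound 2 `COc1ccccc1-c1c[nH]c(=S)s1` gives 12%
compound 3 `S=c1[nH]cc(-c2ccccc2)s1` gives 16%

Compound 3 stands second highest of the three numbers in this assay. Its nearest neighbour is compound 2, which lies within the scatter of it, as the step of a number 4 percentage points higher from compound 2 to compound 3 (within the scatter) shows. The furthest is compound 1, and that step, a number 13 percentage points lower from compound 1 to compound 3 (beyond the scatter), lies beyond the scatter; so does a number 17 percentage points lower from compound 1 to compound 2 (beyond the scatter).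

The next compound, compound 4 `COc1ccc(-c2c[nH]c(=S)s2)cc1`, differs from compound 3 by methoxy in place of hydrogen on an aromatic carbon.

Going by the values given here, the one measured step that bears on this change is the reverse one, from compound 2 to compound 3, where a methoxy on the same six-membered ring is replaced by hydrogen and the number moves by a number 4 percentage points higher from compound 2 to compound 3 (within the scatter), within the scatter. Among the compounds with values here, compound 2 carries its methoxy at another carbon of that ring, so the comparison is not exact; still, nothing among the measured compounds suggests that a methoxy on this ring moves the read-out by a large amount. A step of about a number 2 percentage points lower from compound 3 to compound 4 (within the scatter) is therefore expected, with no clear direction beyond the scatter.

Compound 4 is expected to give about 14% in this assay, within a range of 4% to 28%.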

Compound 4, a percentage reported as inhibition, at one concentration (the size of the read-out at that concentration, not a potency): 0%
Compound 4: middle estimate off by 14 percentage points, on the high side; the measured number lies below the stated range.
By their numbers in this assay, from the lowest: compound 4; then compounds 2 and 3 (each within the scatter of the next); then compound 1.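

Methoxy on an aromatic carbon para to a group of 6 heavy atoms gives a number 16 percentage points lower from compound 3 to compound 4 (beyond the scatter) in this assay and so registers as a real change on this ring, whereas a number 4 percentage points higher from compound 2 to compound 3 (within the scatter) gave no sign of one. The same group at another carbon of the ring therefore does not predict this position: compound 2 gives 12% and compound 4 gives 0% in this assay on otherwise the same structure, so methoxy on this ring cannot be treated as a single change independent of its carbon. Nothing available explains why the number drops at this position.

It remains open whether the loss belongs to methoxy itself or would follow any group at this carbon, since no other group is shown here, and an amine, a carboxylic acid or a longer chain such as ethoxy would help separate those cases. Going by these compounds alone, with one tested concentration and only low numbers so far, the series also gives no potency, so the size of this step says little about how these compounds would rank at other concentrations.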